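The source may hold more compounds than are shown below. What is called first, only, known or untested is meant among the compounds shown, and "the series" means these compounds.

Compound 1, `CCN1CCN(C(=S)SCCCOc2ccc3c(=O)c(-c4ccc(OC)cc4)coc3c2)CC1`, is one of three measured members of a series that shares a common core and differs only in the group attached to the thiocarbonyl carbon at the end of the three-carbon chain. In a functional assay on ECa-109 cells for inhibition, with ECa-109 cell line (Homo sapiens) as the target, read by MTT assay, with a stated time of 48 h (a lower number here means a stronger inhibitor, a higher number a weaker inhibitor), compound 1 gives 36900 nM, numerically the highest of the three numbers, although its distance to each of the others stays within the scatter. Compound 2, `COc1ccc(-c2coc3cc(OCCCSC(=S)N4CCOCC4)ccc3c2=O)cc1`, gives 34000 nM in this assay, and compound 3, `COc1ccc(-c2coc3cc(OCCCSC(=S)N4CCN(C(C)=O)CC4)ccc3c2=O)cc1`, gives 24700 nM. The three steps between them are small: a 1.1-fold lower number from compound 1 to compound 2 (0.04 log units; within the scatter), a 1.5-fold lower number from compound 1 to compound 3 (0.17 log units; within the scatter) and a 1.4-fold lower number from compound 2 to compound 3 (0.14 log units; within the scatter).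

Compound 4, `COc1ccc(-c2coc3cc(OCCCSC(=S)N4CCN(C)CC4)ccc3c2=O)cc1`, has not yet been measured. Against compound 1 the difference is hydrogen in place of methyl on a saturated chain carbon bound to an amine nitrogen in a ring. For the measured compounds named here, the step that bears most directly on it is the one from compound 1 to compound 3, where the ethyl on the amine nitrogen in the ring gave way to acetyl with no step beyond the scatter; the step from compound 1 to compound 2, which swapped the whole ring, was likewise within the scatter. Trimming ethyl to methyl is a smaller change than either, so in this assay compound 4 is expected to show no step beyond the scatter, a 1.1-fold lower number from compound 1 to compound 4 (0.04 log units; within the scatter). Compound 4 is therefore estimated at 34000 nM, with a range from 16000 nM to 75000 nM.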

Compound 4, half-maximal inhibitory concentration: 24200 nM
The estimate for compound 4 lay 1.4-fold (0.15 log units) above the measured number; low and high end bracket the measured number.
By their numbers in this assay, from the lowest: compounds 4, 3, 2 and 1 (each within the scatter of the next).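

Cutting the ethyl of compound 1 back to the methyl of compound 4 is the first change shown on the saturated chain carbon bound to the amine nitrogen in the ring, and in this assay it comes to a 1.5-fold lower number from compound 1 to compound 4 (0.18 log units; within the scatter) with the rest of the molecule held constant. Compound 4 also adds two comparisons with the other groups on the thiocarbonyl carbon, a 1.0-fold lower number from compound 3 to compound 4 (0.01 log units; within the scatter) for methyl in place of acetyl and a 1.4-fold lower number from compound 2 to compound 4 (0.15 log units; within the scatter) for 4-methylpiperazin-1-yl in place of morpholin-4-yl, so that all four groups shown now lie within the scatter of one another in this assay. No measurement offered alongside these numbers accounts for this lack of separation.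

On these data alone, whether any group on the amine nitrogen can move the number beyond the scatter remains open, for example a plain hydrogen, a benzyl or a longer chain ending in a carboxylic acid. Every compound shown also shares the same core, the same 4-methoxyphenyl group and the same chain to the thiocarbonyl carbon, so the effect of changing any of these remains unknown.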